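Replacing the aromatic ring on the amide nitrogen

The source may report more compounds than this note shows. Statements on the series, on what has been measured and on what is new or still open speak of the compounds shown alone.

Of the compounds shown here, three that share one core have been measured in an assay on isolated protein for inhibition of glutathione S-transferase P (Homo sapiens), with a stated time of 10 min; a lower number here means a stronger inhibitor, a higher number a weaker inhibitor. Compound 1 `COc1ccccc1NC(=O)CCC(=O)OCCCCCCSc1ccc([N+](=O)[O-])c2nonc12` gives 4050 nM. Compound 2 `O=C(CCC(=O)OCCCCCCSc1ccc([N+](=O)[O-])c2nonc12)Nc1cccc(Cl)c1` gives 28800 nM, and compound 3 `O=C(CCC(=O)OCCCCCCSc1ccc([N+](=O)[O-])c2nonc12)Nc1ccc(F)cc1` gives 8570 nM. On these numbers compound 3 stands second highest of the three, with its neighbours set by a 2.1-fold higher number from compound 1 to compound 3 (0.33 log units; beyond the scatter) and a 3.4-fold lower number from compound 2 to compound 3 (0.53 log units; beyond the scatter).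

The next compound, compound 4 `O=C(CCC(=O)OCCCCCCSc1ccc([N+](=O)[O-])c2nonc12)NCCN1CCCC1`, differs from compound 3 in one place: 2-(pyrrolidin-1-yl)ethyl in place of 4-fluorophenyl on an amide-type nitrogen.

Every measured step exchanges one ring for another on the amide-type nitrogen; besides the two steps just quoted there is a 7.1-fold higher number from compound 1 to compound 2 (0.85 log units; beyond the scatter). Together they show that this position does respond to change, yet only modestly across the three rings tried. Among the measured compounds shown here, none of them removes the aromatic ring altogether, which is what the step to compound 4 does, so no measured pair speaks directly to this change. Since the three measured variations stayed within a modest spread, a modest step is expected here too, most likely toward a higher number, with wide uncertainty either way. Compound 4 is estimated at 15000 nM, within a range from 4000 nM to 60000 nM. That estimate means a step of a 1.8-fold higher number from compound 3 to compound 4 (0.24 log units; within the scatter) is expected.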

Compound 4, half-maximal inhibitory concentration: 460 nM
Compound 4: middle estimate off by 33-fold (1.51 log units), on the high side, outside the stated range (below it).
By their numbers in this assay, from the lowest: compound 4; then compound 1; then compound 3; then compound 2.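

With 2-(pyrrolidin-1-yl)ethyl on the amide-type nitrogen, this assay gives a 19-fold lower number from compound 3 to compound 4 (1.27 log units; beyond the scatter), a 63-fold lower number from compound 2 to compound 4 (1.80 log units; beyond the scatter) and an 8.8-fold lower number from compound 1 to compound 4 (0.94 log units; beyond the scatter). Each of these steps is beyond the scatter, so compound 4 is the strongest inhibitor of the four, and an aromatic ring on this nitrogen is clearly not required for inhibition here. The data shown offer no measured explanation for why this exchange lowers the number.

The step changes several things at once: the aromatic ring leaves, while a two-part group made up of an ethyl chain and a non-aromatic ring containing a nitrogen enters, so the compounds shown cannot say which of these parts accounts for the result. A plain alkyl group such as hexyl would test the need for the ring nitrogen, while a 2-(dimethylamino)ethyl group, a 2-(piperidin-1-yl)ethyl group or a longer chain leading to the pyrrolidine would show how much the ring and its distance from the amide matter.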